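The source may report more compounds than this note shows. Statements on the series, on what has been measured and on what is new or still open speak of the compounds shown alone.

Measured in a functional assay on A2780 cells (Homo sapiens) for inhibition; a higher number here means a weaker inhibitor, a lower number a stronger inhibitor:
- Compound 1 `CCNC(=O)c1noc(-c2cc(C(C)C)c(O)cc2O)c1-c1cc(CO)no1`: 5 nM
- Compound 2 `CCNC(=O)c1noc(-c2cc(C(C)C)c(O)cc2O)c1-c1cc(C(=O)O)no1`: 20000 nM
- Compound 3 `CCNC(=O)c1noc(-c2cc(C(C)C)c(O)cc2O)c1-c1cc(C(N)=O)no1`: 15 nM

Compound 3 stands second highest of the three numbers, close to compound 1 and far from compound 2. The next compound, compound 4 `CCNC(=O)c1noc(-c2cc(C(C)C)c(O)cc2O)c1-c1ccn(C)n1`, keeps the shared core but carries 1-methyl-1H-pyrazol-3-yl in place of 3-carbamoyl-1,2-oxazol-5-yl on an aromatic carbon.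

Within the data shown here, no measured pair swaps this whole group, which leaves only indirect guidance. Two measured steps changed the end of the same group. One is a 3.0-fold higher number from compound 1 to compound 3 (0.48 log units; beyond the scatter), a modest change. The other is a 4000-fold higher number from compound 1 to compound 2 (3.60 log units; beyond the scatter), a large change that brought in a carboxy group, and compound 4 has no carboxy group. The modest step is therefore the closer guide, and a modest rise in this assay seems more likely than a collapse, though the data cannot rule one out. The expected change is a 2.0-fold higher number from compound 3 to compound 4 (0.30 log units; within the scatter). Compound 4 is estimated at 30 nM, with an expected range of 8 nM to 150 nM.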

Compound 4, half-maximal inhibitory concentration: 12 nM
Compound 4: middle estimate off by 2.5-fold (0.40 log units), on the high side, within the range that was stated.
By their numbers in this assay, from the lowest: compound 1; then compounds 4 and 3 (each within the scatter of the next); then compound 2.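

In this assay exchanging the whole 3-carbamoyl-1,2-oxazol-5-yl group for 1-methyl-1H-pyrazol-3-yl gives a 1.3-fold lower number from compound 3 to compound 4 (0.10 log units; within the scatter) and so shows that this position accepts a different ring, not only a different end on the same ring. The entering group has no hydrogen-bond donor, so a donor on this group is not needed for a low number, and the step of a 2.4-fold higher number from compound 1 to compound 4 (0.38 log units; beyond the scatter) is only modest. Set against the carboxy compound, the same group gives a 1700-fold lower number from compound 2 to compound 4 (3.22 log units; beyond the scatter) and leaves 3-carboxy-1,2-oxazol-5-yl as the only group among these four with a very high number. Nothing available explains these differences. The compounds shown leave open whether an aminomethyl group on the 1,2-oxazol-5-yl ring would sit near hydroxymethyl or near carboxy. They also leave open whether the methyl of 1-methyl-1H-pyrazol-3-yl could give way to a longer chain such as propyl.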